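Swapping a side group on a shared anilino-triazine core

This account rests on a few compounds, and the source may have more. Where it says the series, first, only, none or still open, it means among the compounds named here.

Compound 1 `C=CC(=O)Nc1cccc(Nc2ncnc(Nc3ccc(Oc4ccc(OC)cc4)cc3)n2)c1` is recorded as "not determined" (no result reported) in a functional assay on Raji cells (Homo sapiens) for antiproliferative activity, read by CCK-8 assay, with a stated time of 24 h (on this read-out lower numbers stand for stronger inhibition and higher numbers for weaker inhibition), so no number can be given for where it stands. A related compound 2 `CC#CC(=O)Nc1cccc(Nc2ncnc(Nc3ccc(C(=O)N4CCCCC4)cc3)n2)c1`, which carries a different amide and a different end group, gives 4620 nM in this assay. Compound 3 `C=CC(=O)Nc1cccc(Nc2ncnc(Nc3ccc(-c4ccc(F)nc4)cc3)n2)c1` differs from compound 1 by 6-fluoropyridin-3-yl in place of 4-methoxyphenoxy on an aromatic carbon. Going by the values given here, with no measured step on record for this kind of change, the size and direction of its effect in this assay are open, and the only anchor is the single value of compound 2. Compound 3 is therefore expected to give about 3000 nM, with a likely range from 500 nM to 15000 nM.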

Compound 3, half-maximal inhibitory concentration: 3250 nM
Compound 3: the middle estimate sits 1.1-fold (0.03 log units) below what was measured; measured number inside the range.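

In this assay compound 3 gives 3250 nM and compound 1 gives "not determined" (no result reported) so no step can be read between them. The compounds shown leave open how replacing 4-methoxyphenoxy with 6-fluoropyridin-3-yl changes this read-out. No further evidence bears on this result.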